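This account rests on a few compounds, and the source may have more. Where it says the series, first, only, none or still open, it means among the compounds named here.

Measured so far:
compound 1 `CN1CCN(c2ccc3c(c2)c(S(=O)(=O)c2cccc4ccccc24)nn3Cc2ccccc2)CC1`: 2 nM
compound 2 `CN1CCN(c2ccc3[nH]nc(S(=O)(=O)c4c(Cl)cccc4Cl)c3c2)CC1`: 40 nM

In a functional assay on HeLa cells for antagonist activity at 5-hydroxytryptamine receptor 6 (Homo sapiens) (a higher number here means a weaker inhibitor, a lower number a stronger inhibitor), compound 1 gives 2 nM, the lowest of the two numbers. Within the data shown here, compound 2 gives 40 nM, a higher number that lies beyond the scatter; compound 2 differs from compound 1 in more than one place, so no single step is drawn between them and only the two values themselves can be set side by side.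

Compound 3 `CC(C)n1nc(S(=O)(=O)c2cccc3ccccc23)c2cc(N3CCN(C)CC3)ccc21` has not yet been measured. It differs from compound 1 in one place: isopropyl in place of benzyl on an aromatic nitrogen. Among the measured compounds shown here, no measured pair shows this change, so its size is open. The expectation is a small rise in the number from the value of compound 1, 2 nM, of a size that may or may not clear the scatter. Compound 3 is estimated at 5 nM, with a range of 1.5 nM to 20 nM. The expected step is a 2.5-fold higher number from compound 1 to compound 3 (0.40 log units; beyond the scatter).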

Compound 3, half-maximal inhibitory concentration: 1.8 nM
Compound 3: middle estimate off by 2.8-fold (0.44 log units), on the high side; the range from low to high includes it.
By their numbers in this assay, from the lowest: compounds 3 and 1 (each within the scatter of the next); then compound 2.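

In this assay, isopropyl in place of benzyl on the aromatic nitrogen gives a 1.1-fold lower number from compound 1 to compound 3 (0.05 log units; within the scatter), so the two compounds cannot be told apart. For this pair, the position keeps its value without the six-membered aromatic ring of benzyl, and a smaller group with no ring serves as well as the larger one. No data are available that explain why the two groups read alike.

As far as these compounds go, only these two carbon-only groups can be compared at this nitrogen, so it remains open whether a chain ending in an amine, a carboxylic acid or a longer alkyl chain would keep the number in the same range. From the compounds shown here alone, it is also open whether this equivalence of benzyl and isopropyl would hold with a different group elsewhere on the shared core.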